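Hydrogen for Amino on the Chain of Compound 1

The source may report more compounds than this note shows. Statements on the series, on what has been measured and on what is new or still open speak of the compounds shown alone.

Compound 1 `COc1cc(C(N)CC(=O)NCCn2c(C)cc3ccccc32)cc(OC)c1OC` gives 410 nM in an assay on C6 cells for antagonist activity at prostaglandin E2 receptor EP2 subtype (Homo sapiens), read by TR-FRET, with stated times of 10 min and 40 min, tested at 1 uM (a lower number here means a stronger inhibitor, a higher number a weaker inhibitor), the highest of the two numbers in hand. Compound 2 `COc1cccc(/C=C/C(=O)NCCn2c(C)cc3ccccc32)c1` gives 29.2 nM in this assay, a gap from compound 1 that lies beyond the usual scatter. For compound 3 `COc1cc(/C=C/C(=O)N2CCC(n3c(C)cc4ccccc43)C2)cc(OC)c1OC` the reading is a limit of the assay, > 1000 nM, and the limit of > 1000 nM in this assay, at which 1 of the 3 values shown sits, notes that one of the three values sits there. Compound 4 `COc1cc(CCC(=O)NCCn2c(C)cc3ccccc32)cc(OC)c1OC` differs from compound 1 by hydrogen in place of amino on a saturated chain carbon bound to an aromatic carbon and a saturated chain carbon; it keeps the rest of compound 1 and loses only the amino. Since compound 2, which also carries no amino, gives 29.2 nM, a moderate fall in number is expected for the step of a 2.7-fold lower number from compound 1 to compound 4 (0.44 log units; beyond the scatter). Compound 4 is therefore estimated at 150 nM in this assay, within 40 nM to 600 nM.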

Compound 4, antagonist equilibrium constant: 214 nM
The estimate for compound 4 lay 1.4-fold (0.15 log units) below the measured number, and the stated range covers the measured number.
By their numbers in this assay, from the lowest: compound 2; then compounds 4 and 1 (each within the scatter of the next). At a limit, above all of these: compound 3.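

In this assay, hydrogen in place of amino on this saturated chain carbon gives a 1.9-fold lower number from compound 1 to compound 4 (0.28 log units; within the scatter). Compound 1 and compound 4 therefore cannot be told apart here, so the amino shows neither a gain nor a loss at this position. No available evidence bears on this result.

The compounds shown leave open whether a hydroxyl or a carboxylic acid on this same carbon would read apart from amino and hydrogen. They also leave open whether a methylamino group would do so.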